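The compounds below may be only part of what the source reports. "The series", "measured", "known", "first", "only" and "open" are said of these compounds alone.

Within the data shown here, compound 1 `OCc1cc(N2CCCC2)ccc1-c1nc2c(s1)C(O)CCC2` holds the only number in a functional assay on HCT-116 cells (Homo sapiens) for cytotoxicity, read by sulforhodamine B assay, with a stated time of 2 days (a lower number here means a stronger inhibitor, a higher number a weaker inhibitor), where compound 1 gives 21000 nM. Compound 2 `OC1CCCc2nc(-c3ccc(N4CCCC4)cc3)sc21` reaches only the limit of > 100000 nM in this assay. Among the measured compounds shown here, the one measured step, an at least 4.7-fold higher number from compound 1 to compound 2 (0.67 log units; beyond the scatter), is an at least modest weakening. Compound 3 `CN(C)c1ccc(-c2nc3c(s2)C(O)CCC3)c(CO)c1` keeps the hydroxymethyl and differs from compound 1 by dimethylamino in place of pyrrolidin-1-yl on an aromatic carbon. That measured step touches a different place, so it gives no guide, and no change beyond the scatter is expected a 1.2-fold higher number from compound 1 to compound 3 (0.08 log units; within the scatter). Compound 3 is therefore estimated at 25000 nM, with a likely range from 8000 nM to 80000 nM.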

Compound 3, half-maximal inhibitory concentration: 78000 nM
For compound 3 the middle estimate is 3.1-fold (0.49 log units) below the measured one; measured number inside the range.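

The position para to a large group, untouched by the earlier step, also responds to change: dimethylamino in place of pyrrolidin-1-yl brings a 3.7-fold higher number from compound 1 to compound 3 (0.57 log units; beyond the scatter), a modest weakening. In this assay, the ring of compound 1 therefore cannot be swapped for this open amine without some loss. The data shown give no reason for this loss.

From the compounds shown here alone, whether a piperidine or morpholine ring at this place would match pyrrolidin-1-yl remains open. So does whether a primary amine would weaken the number further.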